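The source may hold more compounds than are shown below. What is called first, only, known or untested is meant among the compounds shown, and "the series" means these compounds.

Series of ureas built on an arylurea core with a phenylethyl amine side. Compound 1 `CCc1cccc(NC(=O)N[C@@H](C)c2ccccc2)c1` and compound 3 `CC(C)c1cccc(NC(=O)N[C@@H](C)c2ccccc2)c1` share one core; compound 2 `CCc1ccc(NC(=O)N[C@H](C)c2ccccc2)cc1` and compound 4 `CC(C)c1ccc(NC(=O)N[C@H](C)c2ccccc2)cc1` share another. The difference between the two cores is not broken down here.

In an ADME assay on the whole organism with Oryza sativa as the target, tested at 1 uM (on this read-out lower numbers stand for a stronger effect and higher numbers for a weaker effect at the one concentration tested), compound 1 gives 94%, compound 3 gives 84% and compound 2 gives 47%. Compound 2 stands lowest of the three measured numbers, beyond the scatter from both others.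

From compound 1 to compound 3 the change is methyl in place of hydrogen on a saturated chain carbon bound to an aromatic carbon and a saturated chain carbon, and it made a step of a number 10 percentage points lower from compound 1 to compound 3 (within the scatter). From compound 2 to compound 4 the change is methyl in place of hydrogen on a saturated chain carbon bound to an aromatic carbon and a saturated chain carbon, the same change on the other core. The change occurs twice among the compounds shown.

Within the data shown here, for compound 4 a step of a number 5 percentage points lower from compound 2 to compound 4 (within the scatter) is expected, resting on the one earlier example, because a number 10 percentage points lower from compound 1 to compound 3 (within the scatter) stayed within the scatter. Compound 4 is therefore estimated at 42%, with a range from 25% to 60%, pending measurement.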

Compound 4, a percentage reported as activity, at one concentration (the size of the read-out at that concentration, not a potency): 79%
Beside the measured number, compound 4's estimate is 37 percentage points below it; the measured number lies above the stated range.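

In this assay the change from ethyl to isopropyl gave a number 32 percentage points higher from compound 2 to compound 4 (beyond the scatter) and so did not repeat what the same change did on the core of compound 1. With a single pair on each core, this does not show why the two cores part, nor whether either step would hold for other members of its core. In this series, the step read on one core cannot be carried to the other, as the two examples disagree in size and direction: the same change on two cores in this assay, a number 10 percentage points lower (within the scatter) from compound 1 to compound 3 and a number 32 percentage points higher (beyond the scatter) from compound 2 to compound 4, 42 percentage points apart, beyond the scatter of two such steps

Still open is which part of the difference between the two cores goes with the different outcome, as that difference is not broken down in the compounds shown. Also open, on these data alone, is how the read-out responds on each core when the saturated chain carbon bound to an aromatic carbon and a saturated chain carbon carries something other than these groups, such as a longer chain like tert-butyl, an amine or a carboxylic acid.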